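Cyclopentyl in Place of Chloroethyl on the Urea Chain

This account rests on a few compounds, and the source may have more. Where it says the series, first, only, none or still open, it means among the compounds named here.

Compound 2 `CC(C)c1ccccc1OS(=O)(=O)c1ccc(NC(=O)NCCCCl)cc1` is measured in a functional assay on M21 cells (Homo sapiens) for antiproliferative activity, read by sulforhodamine B assay, with a stated time of 48 h; a lower number here means a stronger inhibitor, a higher number a weaker inhibitor. There compound 2 gives 9300 nM, and compound 1 `CCCNC(=O)Nc1ccc(S(=O)(=O)Oc2ccccc2C(C)C)cc1` gives 5100 nM; the step of a 1.8-fold higher number from compound 1 to compound 2 (0.26 log units; within the scatter) lies within the scatter, so the two stand together. Compound 3 `CC(C)c1ccccc1OS(=O)(=O)c1ccc(NC(=O)NCC2CCCC2)cc1` differs from compound 2 by cyclopentyl in place of 2-chloroethyl on a saturated chain carbon bound to an amide-type nitrogen. For the measured compounds named here, the only measured step, a 1.8-fold higher number from compound 1 to compound 2 (0.26 log units; within the scatter), concerned a chlorine and moved the number little, so it offers only weak guidance on a cyclopentyl. No step beyond the scatter is therefore expected in this assay for compound 3, whose estimate is 6500 nM with a range of 2500 nM to 17000 nM, meaning a 1.4-fold lower number from compound 2 to compound 3 (0.16 log units; within the scatter).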

Compound 3, half-maximal inhibitory concentration: 6600 nM
Beside the measured number, compound 3's estimate is 1.0-fold (0.01 log units) below it, within the range that was stated.
By their numbers in this assay, from the lowest: compounds 1, 3 and 2 (each within the scatter of the next).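

In this assay, exchanging the open chain for a ring on a saturated chain carbon bound to an amide-type nitrogen gives a 1.4-fold lower number from compound 2 to compound 3 (0.15 log units; within the scatter) and a 1.3-fold higher number from compound 1 to compound 3 (0.11 log units; within the scatter), so this position, so far shown only with open chains, also accepts cyclopentyl with no step beyond the scatter. Compound 1, compound 2 and compound 3 therefore stand together. No evidence is given that bears on this result. Still open, on these data alone, is whether an amine, a carboxylic acid or a longer chain at this position would move the number beyond the scatter.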